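The source may hold more compounds than are shown below. What is called first, only, known or untested is meant among the compounds shown, and "the series" means these compounds.

Compound 1 `CCCc1ccc(C(=O)N/N=C/c2ccc3c(c2)no[n+]3[O-])cc1`: > 200000 nM
Compound 2 `CCCOc1ccc(C(=O)N/N=C/c2ccc3c(c2)no[n+]3[O-])cc1`: > 200000 nM
Compound 3 `CCCCc1ccc(C(=O)N/N=C/c2ccc3c(c2)no[n+]3[O-])cc1`: > 200000 nM

These three compounds were tested in an ADME assay on cells (Fibroblast, Homo sapiens) for inhibition, read by MTT assay, with a stated time of 24 h (on this read-out higher numbers stand for weaker inhibition and lower numbers for stronger inhibition), and none of them gave a number. The evidence so far is the limit of > 200000 nM in this assay, at which 3 of the 3 values shown sit. Compound 3 stands at > 200000 nM, which is a limit of the assay and not a measured value.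

Compound 4 `CC(C)c1ccc(C(=O)N/N=C/c2ccc3c(c2)no[n+]3[O-])cc1` carries isopropyl in place of butyl on an aromatic carbon, para to a large group: isopropyl in place of butyl on an aromatic carbon.

Among the compounds with values here, three measured steps bear on this change: a step that the two limits leave unreadable from compound 1 to compound 3, a step that the two limits leave unreadable from compound 2 to compound 3 and a step that the two limits leave unreadable from compound 1 to compound 2. None gives a size to carry over, but all three compounds remain at the same limit across changes in this same substituent. No step beyond the usual scatter is therefore expected in this assay, and no direction can be assigned. The expected change is a step that the limit leaves unreadable from compound 3 to compound 4. The assay will most likely report only a limit again. Compound 4 is estimated at about 220000 nM, with an expected range from 120000 nM to 400000 nM.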

Compound 4, half-maximal inhibitory concentration: > 200000 nM
Compound 4 gave a limit, no number (the forecaster's own chance of this, stated with the estimate: 90%); the middle value lies beyond the limit too.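

The steps linking compound 4 to compound 1, compound 2 and compound 3 cannot be read in this assay: the limit of > 200000 nM in this assay, at which 4 of the 4 values shown sit. These compounds leave open how the four would rank beyond that limit, and whether any other group at this place would give a measurable value in this assay.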